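Sigma-1 Binding: Neopentyl Replaces Benzofuranylcarbonyl on the Piperidine Nitrogen

The source may hold more compounds than are shown below. What is called first, only, known or untested is meant among the compounds shown, and "the series" means these compounds.

Two compounds share a core carrying a bis(4-fluorophenyl)methylthioethylamine chain on a six-membered ring, and they differ only at the amine nitrogen in that ring. Compound 1 `Fc1ccc(CN2CCC(NCCSC(c3ccc(F)cc3)c3ccc(F)cc3)CC2)cc1` gives 13.3 nM in an assay on membranes from Cortex for displacement of a labelled ligand from Sigma non-opioid intracellular receptor 1 (Cavia porcellus), read by scintillation counting, with a stated time of 120 min (a lower number here means a stronger inhibitor, a higher number a weaker inhibitor), while compound 2 `O=C(c1cc2ccccc2o1)N1CCC(NCCSC(c2ccc(F)cc2)c2ccc(F)cc2)CC1` gives 304 nM in this assay, the highest of the two numbers and set apart from compound 1 by a 23-fold higher number from compound 1 to compound 2 (1.36 log units; beyond the scatter). Compound 3 `CC(C)(C)CN1CCC(NCCSC(c2ccc(F)cc2)c2ccc(F)cc2)CC1` now replaces that group: neopentyl in place of (1-benzofuran-2-yl)carbonyl on an amine nitrogen in a ring. Among the measured compounds shown here, only one measured step bears on this change, the large one from compound 1 to compound 2, in which a group without a carbonyl was exchanged for one with it; compound 3 reverses that direction, bringing in a group with no ring and no hydrogen-bond acceptors. The estimated step is therefore a large fall in the number, a 12-fold lower number from compound 2 to compound 3 (1.08 log units; beyond the scatter), and compound 3 is expected to give about 25 nM in this assay, within 8 nM to 80 nM.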

Compound 3, inhibition constant: 315 nM
For compound 3 the middle estimate is 13-fold (1.10 log units) below the measured one, and the stated range ends below it.
By their numbers in this assay, from the lowest: compound 1; then compounds 2 and 3 (each within the scatter of the next).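

In this assay, neopentyl in place of (1-benzofuran-2-yl)carbonyl on an amine nitrogen in a ring gives a 1.0-fold higher number from compound 2 to compound 3 (0.02 log units; within the scatter), so these two groups are not told apart at this position, although one has a carbonyl and rings and the other has neither. The change at the same position from compound 1 is large, with tert-butyl in place of 4-fluorophenyl on a saturated chain carbon giving a 24-fold higher number from compound 1 to compound 3 (1.37 log units; beyond the scatter), so the absence of a carbonyl does not by itself go with the low number of compound 1. No evidence is available to explain why the 4-fluorobenzyl group stands apart here.

As far as these compounds go, whether a plain benzyl or a (1-benzofuran-2-yl)methyl group would stay with compound 1 remains open. So does whether an open-chain group such as n-butyl would stay with compound 3.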